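Phenyl in Place of Fluoro on a Shared Pyridinone Core

The compounds below may be only part of what the source reports. "The series", "measured", "known", "first", "only" and "open" are said of these compounds alone.

Compound 2 `Cc1c(F)cc(C(=O)NC2CCCCCC2)c(=O)n1Cc1ccc(F)cc1` carries a fluoro group on the aromatic carbon of its core. In an assay on HEK293 cells for inhibition of Monoacylglycerol lipase ABHD6 (Homo sapiens), read by scintillation counting, with stated times of 30 min and 5 min (a lower number here means a stronger inhibitor, a higher number a weaker inhibitor), compound 2 gives > 10000 nM, which is a limit of the assay and not a number. Among the measured compounds shown here, the one measured step into compound 2 comes from compound 1 `Cc1c(-c2ccc(F)cc2)cc(C(=O)NC2CCCCCC2)c(=O)n1Cc1ccc(F)cc1`, in which a 4-fluorophenyl group sits at the same position. In this assay compound 1 gives > 10000 nM, again a limit. The step that the two limits leave unreadable from compound 1 to compound 2 therefore cannot be sized, and the limit of > 10000 nM in this assay, at which 2 of the 2 values shown sit, shows that both measured values sit at that limit. Compound 3 `Cc1c(-c2ccccc2)cc(C(=O)NC2CCCCCC2)c(=O)n1Cc1ccc(F)cc1` differs from compound 2 by phenyl in place of fluoro on an aromatic carbon. For the measured compounds named here, since the only measured change at this position, between two limits, gives no readable direction, the estimated step that the limit leaves unreadable from compound 2 to compound 3 is expected to leave compound 3 near the same limit. Compound 3 is therefore expected to give about 15000 nM, in a range from 4000 nM to 60000 nM.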

Compound 3, half-maximal inhibitory concentration: > 10000 nM
Compound 3: a limit, no number; the forecaster's own chance of this, stated with the estimate: 85%; the middle value does not contradict the limit.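

In this assay compound 3 gives > 10000 nM which is a limit and not a number. The steps among compound 1, compound 2 and compound 3 therefore cannot be read: the limit of > 10000 nM in this assay, at which 3 of the 3 values shown sit. Still open, from the compounds shown here alone, is how strongly each compound inhibits the enzyme, and whether the group at this position changes that at all.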